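A few compounds are considered here, and "the series" means these few. Any claim that something is new, unique, unknown or untested is made for them only; others in the source may bear on it.

Measured compounds:
- compound 1 `COc1ccc(-c2cc3ccccc3c(-c3cccc(OC)c3)n2)cc1`: 860 nM
- compound 2 `COc1ccc(-c2cc3cc(C)ccc3c(-c3cccc(O)c3)n2)c(C)c1`: 560 nM

In a functional assay on T47D cells (Homo sapiens) for cytotoxicity, read by CCK-8 assay and cell counting, with a stated time of 72 h (on this read-out lower numbers stand for stronger inhibition and higher numbers for weaker inhibition), compound 1 gives 860 nM and compound 2 gives 560 nM; the two numbers lie within the usual scatter of each other, so no order between them can be stated. Going by the values given here, compound 2 and compound 1 differ in more than one place, and no single step between them is recorded; only their two values are known.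

Compound 3 `COc1ccc(-c2cc3cc(C)ccc3c(-c3cccc(N)c3)n2)c(C)c1` has not yet been measured in this assay. It differs from compound 2 by amino in place of hydroxy on an aromatic carbon. Among the compounds with values here, no pair of measured compounds shows this change, so its size is not known from the series. The expected step from compound 2 to compound 3 is a 1.3-fold higher number from compound 2 to compound 3 (0.10 log units; within the scatter), that is, none beyond the scatter in either direction. For compound 3 the expected value in this assay is 700 nM, with a range from 250 nM to 2000 nM.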

Compound 3, half-maximal inhibitory concentration: 740 nM
For compound 3 the middle estimate is 1.1-fold (0.02 log units) below the measured one; measured number inside the range.
By their numbers in this assay, from the lowest: compounds 2, 3 and 1 (each within the scatter of the next).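

In this assay, going by these compounds alone, the one single-place step reads a 1.3-fold higher number from compound 2 to compound 3 (0.12 log units; within the scatter), so amino in place of hydroxy on this aromatic carbon, meta to a large group, has no effect that can be separated from the scatter. The step from 3-hydroxyphenyl to 3-aminophenyl therefore shows that the oxygen is not required at this position for a value of this order, with compound 3 at 740 nM. The data available give no explanation for this equivalence.

Still open, as far as these compounds go, is how this position responds to groups that differ more from hydroxy and amino, such as an acetamide, a carboxylic acid or a plain hydrogen. Also open, from the compounds shown here alone, is whether the same exchange reads alike on the core of compound 1.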